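Phenoxy Replaced by a Directly Bound Oxadiazole

This account rests on a few compounds, and the source may have more. Where it says the series, first, only, none or still open, it means among the compounds named here.

Of the compounds shown here, three sharing one core have been tested in an assay on CHO-K1 cells for binding affinity to 5-hydroxytryptamine receptor 1B (Homo sapiens); a lower number here means a stronger inhibitor, a higher number a weaker inhibitor. Compound 1 `Cc1noc(Cc2ccc3[nH]cc([C@H]4C[C@H](N(C)C)C4)c3c2)n1` gives 1510 nM, compound 2 `Cc1nc(Cc2ccc3[nH]cc([C@H]4C[C@H](N(C)C)C4)c3c2)n[nH]1` gives 3890 nM, and compound 3 `CN(C)[C@H]1C[C@H](c2c[nH]c3ccc(Oc4ccccc4)cc32)C1` gives 97.7 nM, the lowest of the three numbers. Compound 4 `Cc1noc(-c2ccc3[nH]cc([C@H]4C[C@H](N(C)C)C4)c3c2)n1` differs from compound 3 by 3-methyl-1,2,4-oxadiazol-5-yl in place of phenoxy on an aromatic carbon. This change reverses part of a step already seen: a 15-fold lower number from compound 1 to compound 3 (1.19 log units; beyond the scatter), where the same oxadiazole sat on a saturated chain carbon rather than the ring; a 40-fold lower number from compound 2 to compound 3 (1.60 log units; beyond the scatter) points the same way. For the measured compounds named here, no measured compound carries this ring on the aromatic carbon itself, so the size is uncertain. Compound 4 is therefore expected to give a higher number, a step of a 7.2-fold higher number from compound 3 to compound 4 (0.86 log units; beyond the scatter), because compound 1 gave 1510 nM. The estimate for compound 4 is 700 nM, between 200 nM and 3000 nM.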

Compound 4, half-maximal inhibitory concentration: 832 nM
For compound 4 the middle estimate is 1.2-fold (0.08 log units) below the measured one; the range from low to high includes it.
By their numbers in this assay, from the lowest: compound 3; then compounds 4 and 1 (each within the scatter of the next); then compound 2.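

Attached directly to the aromatic carbon, 3-methyl-1,2,4-oxadiazol-5-yl does not match phenoxy in this assay and gives an 8.5-fold higher number from compound 3 to compound 4 (0.93 log units; beyond the scatter) with the ring-bound oxadiazole still well short of phenoxy. With or without the saturated chain carbon, the oxadiazole compounds stay within the scatter of each other, with a 1.8-fold lower number from compound 1 to compound 4 (0.26 log units; within the scatter) as the step between them. The triazole comparison spans two differences in one place, giving a 4.7-fold lower number from compound 2 to compound 4 (0.67 log units; beyond the scatter) in favour of the directly bound oxadiazole.

Nothing given here accounts for these differences. From the compounds shown here alone, whether a phenyl group bonded directly to this aromatic carbon, without the ether oxygen, or an amine there would come close to phenoxy remains open.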